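Bromo to Cyclopentyl on the Thiophene-Bearing Amine Series

This account rests on a few compounds, and the source may have more. Where it says the series, first, only, none or still open, it means among the compounds named here.

Compound 1: `CCc1csc(CN[C@@H]2C[C@H]3C[C@@H]([C@H]2C)C3(C)C)c1`, 25000 nM
Compound 2: `C[C@H]1[C@H](NCc2cc(Br)cs2)C[C@H]2C[C@@H]1C2(C)C`, 6250 nM
Compound 3: `Cc1csc(CN[C@@H]2C[C@H]3C[C@@H]([C@H]2C)C3(C)C)n1`, > 100000 nM

In an ADME assay on MDCK cells (Canis lupus familiaris) for cytotoxicity, read by microscopy, with a stated time of 48 h (a higher number here means that more compound is tolerated, a lower number that less compound is tolerated), compound 2 gives the lowest of the two numbers shown, with compound 1 as its nearest neighbour. The value of compound 3 in this assay is a limit of the assay rather than a number, where one of the three values shown sits (the limit of > 100000 nM in this assay, at which 1 of the 3 values shown sits). Compound 4, `C[C@H]1[C@H](NCc2cc(C3CCCC3)cs2)C[C@H]2C[C@@H]1C2(C)C`, is not yet measured; it differs from compound 2 in one place: cyclopentyl in place of bromo on an aromatic carbon.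

Among the compounds with values here, one measured step bears on this change: a 4.0-fold lower number from compound 1 to compound 2 (0.60 log units; beyond the scatter), a modest step in which an alkyl group gave way to bromo. Within the data shown here, compound 4 moves the other way, from bromo to a larger alkyl group, so a modest step back toward a higher number is expected, though the size of cyclopentyl has no measured counterpart here. The step from compound 2 to compound 4 is expected to be a 2.0-fold higher number from compound 2 to compound 4 (0.30 log units; within the scatter). Compound 4 is therefore estimated at 12500 nM, within 3000 nM to 50000 nM.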

Compound 4, minimum cytotoxic concentration: 1560 nM
The estimate for compound 4 lay 8.0-fold (0.90 log units) above the measured number, outside the stated range (below it).
By their numbers in this assay, from the lowest: compound 4; then compound 2; then compound 1. At a limit, above all of these: compound 3.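

In this assay, the aromatic carbon two ring bonds from the ring sulfur proved sensitive to which alkyl group it carries, since cyclopentyl in place of bromo gave a 4.0-fold lower number from compound 2 to compound 4 (0.60 log units; beyond the scatter) and cyclopentyl in place of ethyl gave a 16-fold lower number from compound 1 to compound 4 (1.20 log units; beyond the scatter) at the same place. An alkyl group here therefore does not by itself give a higher number than bromo: ethyl lies above bromo and cyclopentyl below it, so the earlier step alone did not tell the direction for every alkyl group. Nothing measured in this set accounts for this reversal.

The compounds shown leave open where a propyl chain or a cyclopropyl ring would fall relative to ethyl and cyclopentyl at this carbon. They also leave open whether an amine or a carboxylic acid there would raise the number.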